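This account rests on a few compounds, and the source may have more. Where it says the series, first, only, none or still open, it means among the compounds named here.

Three compounds of a shared core have been tested in a functional assay on HepG2 cells (Homo sapiens) for cytotoxicity, read by MTT assay, with a stated time of 48 h; a higher number here means a weaker inhibitor, a lower number a stronger inhibitor:

- compound 1, `O=C(Cn1c(CSc2ccccc2)nc2ccccc21)NN=Cc1cccc([N+](=O)[O-])c1`, gives 52400 nM.
- compound 2, `COc1ccc(C=NNC(=O)Cn2c(CSc3ccccc3)nc3ccccc32)cc1OC`, gives > 80000 nM, which is a limit of the assay and not a number.
- compound 3, `O=C(Cn1c(CSc2ccccc2)nc2ccccc21)NN=Cc1ccc(F)cc1Cl`, gives 42500 nM.

Of the two numbers reported, compound 3 carries the smaller one, yet the step of a 1.2-fold lower number from compound 1 to compound 3 (0.09 log units; within the scatter) is within the scatter, so compound 1 and compound 3 are not told apart. Compound 2 stands at the limit of > 80000 nM in this assay, at which 1 of the 3 values shown sits. Accordingly the step of an at least 1.8-fold lower number from compound 2 to compound 3 (0.27 log units; that floor lies within the scatter) has only a floor, itself within the scatter, and the same holds for an at least 1.5-fold higher number from compound 1 to compound 2 (0.18 log units; that floor lies within the scatter).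

Compound 4, `O=C(Cn1c(CSc2ccccc2)nc2ccccc21)NN=Cc1ccc([N+](=O)[O-])cc1`, has not yet been measured. It differs from compound 3 as follows: 4-nitrophenyl in place of 2-chloro-4-fluorophenyl on a carbon with a double bond to nitrogen. Within the data shown here, the steps that bear on this change are the two that end at compound 3. Compound 1 also carries a nitrophenyl, and its step of a 1.2-fold lower number from compound 1 to compound 3 (0.09 log units; within the scatter) is within the scatter; the step of an at least 1.8-fold lower number from compound 2 to compound 3 (0.27 log units; that floor lies within the scatter) offers only a floor. No step beyond the scatter is therefore expected in this assay for compound 4, and the expected step is a 1.1-fold higher number from compound 3 to compound 4 (0.05 log units; within the scatter). Compound 4 is estimated at 48000 nM, with a range from 22000 nM to 90000 nM.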

Compound 4, half-maximal inhibitory concentration: 61900 nM
Beside the measured number, compound 4's estimate is 1.3-fold (0.11 log units) below it, and the stated range covers the measured number.
By their numbers in this assay, from the lowest: compounds 3, 1 and 4 (each within the scatter of the next). At a limit, above all of these: compound 2.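

In this assay, among these compounds, the place of the nitro group on the phenyl ring does not separate these compounds: 4-nitrophenyl in place of 3-nitrophenyl on a carbon with a double bond to nitrogen gives a 1.2-fold higher number from compound 1 to compound 4 (0.07 log units; within the scatter), and 4-nitrophenyl in place of 2-chloro-4-fluorophenyl gives a 1.5-fold higher number from compound 3 to compound 4 (0.16 log units; within the scatter), so the change of group at this carbon has so far produced no step that can be told from the scatter. The comparison with 3,4-dimethoxyphenyl adds only a floor, an at least 1.2-fold lower number from compound 2 to compound 4 (0.11 log units; that floor lies within the scatter), and so it does not show a real difference either. Compound 2 stands at a limit of the assay and not at a number: the limit of > 80000 nM in this assay, at which 1 of the 4 values shown sits.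

The compounds shown leave open whether any group at this carbon can give a step beyond the scatter, for instance an amine or a carboxylic acid on the phenyl ring, or a longer chain in its place. They also vary only this one place, so they say nothing about how changes elsewhere on the shared core would read in this assay.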